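Replacing methyl with oxolan-2-yl on the side chain

This account rests on a few compounds, and the source may have more. Where it says the series, first, only, none or still open, it means among the compounds named here.

Measured in a functional assay on KARPAS-422 cells (Homo sapiens) for antiproliferative activity, read by resazurin assay, with a stated time of 72 h; on this read-out higher numbers stand for weaker inhibition and lower numbers for stronger inhibition:
compound 1 `Cc1cc(C)c(CN2CCc3c(Cl)cc([C@@H](CO)[C@@H]4CCOC4)c(Cl)c3C2=O)c(=O)[nH]1`: 3950 nM
compound 2 `Cc1cc(C)c(CN2CCc3c(Cl)cc([C@H](C)CO)c(Cl)c3C2=O)c(=O)[nH]1`: 186 nM
compound 3 `Cc1cc(C)c(CN2CCc3c(Cl)cc(C(CO)C4CCOC4)c(Cl)c3C2=O)c(=O)[nH]1`: 1040 nM; 17 nM (2 entries)

Compound 2, at 186 nM, has the lower of the two single numbers, and compound 3 offers no single number. Compound 4 `Cc1cc(C)c(CN2CCc3c(Cl)cc([C@@H](CO)[C@@H]4CCCO4)c(Cl)c3C2=O)c(=O)[nH]1` has not yet been measured in this assay. It carries oxolan-2-yl in place of methyl on a saturated chain carbon bound to an aromatic carbon and a saturated chain carbon.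

Among the measured compounds shown here, only one measured step bears on this change, and it involves the isomeric oxolan-3-yl group: a 21-fold lower number from compound 1 to compound 2 (1.33 log units; beyond the scatter). Read in reverse, that large step suggests a higher number when a ring replaces methyl. The guidance is loose, given (the several entries of compound 3 in this assay, 1040 nM; 17 nM (2 entries)), one entry lying on either side of the value of compound 2. It is further weakened by the fact that one of compounds 1 and 3 is drawn with a defined configuration and the other without, at the place where they differ.

Drawing on compound 1 at 3950 nM, the expected change is upward but smaller, an estimated 3.8-fold higher number from compound 2 to compound 4 (0.58 log units; beyond the scatter). For compound 4 the estimated value is 700 nM, with an expected range from 60 nM to 5000 nM.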

Compound 4, half-maximal inhibitory concentration in the KARPAS-422 assay: 1220 nM
Compound 4: the middle estimate sits 1.7-fold (0.24 log units) below what was measured; the measured number falls inside the stated range.
By their numbers in the KARPAS-422 assay, from the lowest: compound 2; then compound 4; then compound 1.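

In the KARPAS-422 assay, oxolan-2-yl on this saturated chain carbon also falls behind methyl, a 6.6-fold higher number from compound 2 to compound 4 (0.82 log units; beyond the scatter), so the loss seen earlier is not confined to oxolan-3-yl. The two rings can now also be set against each other, a 3.2-fold lower number from compound 1 to compound 4 (0.51 log units; beyond the scatter), which shows that the choice between oxolan-2-yl and oxolan-3-yl itself moves the number at this position. Against that loss, the exchange of methyl for oxolan-2-yl goes with a gain in solubility: the measured solubility of compound 2, 131000 nM, and of compound 4, 550000 nM, a 4.2-fold higher number (0.62 log units; beyond the scatter) In a physicochemical assay for solubility, measured as kinetic solubility (a higher number here means a more soluble compound, a lower number a less soluble compound), compound 2 gives 131000 nM and compound 4 gives 550000 nM.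

The compounds shown leave open how much of the gap between compound 1 and compound 4 comes from the ring's attachment and how much from configuration, as each ring appears here in a single drawn form. Also open, going by these compounds, is whether an open chain such as methoxymethyl at this carbon could match the potency of compound 2 and the solubility of compound 4.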